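One Swap, Two Cores: Moving a Chlorine on a Benzyl Thioether

The source may hold more compounds than are shown below. What is called first, only, known or untested is meant among the compounds shown, and "the series" means these compounds.

Measured so far:
Compound 1, `COc1ccc(C2N=C(SCc3ccccc3Cl)NC(C)=C2C(=O)Nc2ccc(F)cc2)cc1OC`, gives 39.2%.
Compound 2, `COc1ccc(C2N=C(SCc3cccc(Cl)c3)NC(C)=C2C(=O)Nc2ccc(F)cc2)cc1OC`, gives 20.1%.
Compound 3, `CC1=C(C(=O)Nc2ccc(Br)cc2)C(c2ccc(Cl)cc2Cl)N=C(SCc2ccccc2Cl)N1`, gives 38.1%.

All three values come from a functional assay on the whole organism (artery, strain albino) with Rattus norvegicus as the target, with a stated time of 360 min, at a dose of 10 mg/kg by the oral route; a higher number here means more inhibition at the dose given (going by the name of the read-out), a lower number less inhibition. Compound 1 and compound 2 share a core and differ in one place: 3-chlorophenyl in place of 2-chlorophenyl on a saturated chain carbon bound to a sulfur. That change cost a number 19.1 percentage points lower from compound 1 to compound 2 (beyond the scatter), a step beyond the scatter. Compound 3 carries a different core; how it differs from compound 1 is not broken down here, and the two values for compound 1 and compound 3 sit within the scatter of each other, so no order between them is claimed.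

Compound 4, `CC1=C(C(=O)Nc2ccc(Br)cc2)C(c2ccc(Cl)cc2Cl)N=C(SCc2cccc(Cl)c2)N1`, has not yet been measured in this assay. It differs from compound 3 as follows: 3-chlorophenyl in place of 2-chlorophenyl on a saturated chain carbon bound to a sulfur. This is the same change as that from compound 1 to compound 2, cut one bond further out as (2-chlorobenzyl)sulfanyl to (3-chlorobenzyl)sulfanyl, made at the same place and seen only once before among these compounds.

Among the compounds with values here, on the single precedent, compound 4 is expected to fall below compound 3 by roughly a number 17.1 percentage points lower from compound 3 to compound 4 (beyond the scatter), because the same move gave a number 19.1 percentage points lower from compound 1 to compound 2 (beyond the scatter). Within the data shown here, with only one example, and that on a different core, the range is kept wide. Compound 4 is estimated at 21%, between 5% and 38%.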

Compound 4, a percentage reported as inhibition, in the whole organism at one dose (the size of the read-out at that dose, not a potency): 20.6%
Compound 4: middle estimate off by 0.4 percentage points, on the high side; the measured number falls inside the stated range.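

In this assay, 3-chlorobenzyl in place of 2-chlorobenzyl on the core of compound 3 gave a number 17.5 percentage points lower from compound 3 to compound 4 (beyond the scatter). Set beside the earlier case, the two steps agree in direction and do not differ in size: the same change on two cores in this assay, a number 19.1 percentage points lower (beyond the scatter) from compound 1 to compound 2 and a number 17.5 percentage points lower (beyond the scatter) from compound 3 to compound 4, 1.6 percentage points apart, within the scatter of two such steps Within this series, the change therefore carried from the core of compound 1 to the core of compound 3 with its size intact, but that reading rests on only two pairs of compounds, at one dose and one time point, and it shows neither that the step would hold on any further core nor why the compounds with the 3-chlorobenzyl group give the lower numbers.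

The compounds shown leave open how an unsubstituted benzyl group, a fluorobenzyl group or a plain alkyl chain would read in place of the two chlorobenzyl groups, so the result cannot yet be extended beyond this one swap. They also leave open whether the same step would appear on a core that carries an amine or a carboxylic acid, since both cores shown here keep their amide and both pairs respond alike only as far as these four compounds go.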